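This account rests on a few compounds, and the source may have more. Where it says the series, first, only, none or still open, it means among the compounds named here.

Working notes on the series.

The shared core carries a sulfamate-bearing aryl joined to a furan that is amidated with a methylated aniline. Among the measured compounds shown here, compound 3 `Cc1cccc(F)c1N(C)C(=O)c1ccc(-c2ccc(OS(N)(=O)=O)cc2)o1` gives 150 nM in an assay on T47D cells for inhibition of Steryl-sulfatase (Homo sapiens), read by HPLC, with a stated time of 24 h; on this read-out lower numbers stand for stronger inhibition and higher numbers for weaker inhibition; it stands second highest of the three numbers measured so far. Compound 1 `Cc1cc(-c2ccc(C(=O)N(C)c3ccccc3C)o2)ccc1OS(N)(=O)=O` gives 570 nM in this assay, and compound 2 `Cc1ccccc1N(C)C(=O)c1ccc(-c2ccc(OS(N)(=O)=O)c(F)c2)o1` gives 17 nM in this assay. For the measured compounds named here, the one measured single-point step, a 34-fold lower number from compound 1 to compound 2 (1.53 log units; beyond the scatter), concerns the ring that carries the sulfamate, not the amide-side ring; it therefore does not bear directly on the change now at hand. Going by the values given here, the values of compound 3 and compound 1 show that the amide-side ring and the sulfamate-side ring both move the number, but no single-point step between them is available.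

Compound 4 `Cc1c(F)cccc1N(C)C(=O)c1ccc(-c2ccc(OS(N)(=O)=O)cc2)o1` differs from compound 3 by 3-fluoro-2-methylphenyl in place of 2-fluoro-6-methylphenyl on an amide-type nitrogen. Among the compounds with values here, no measured step separates two placements of fluoro on the amide-side ring, so no direction can be read from the data. The expectation is a step of a 1.3-fold higher number from compound 3 to compound 4 (0.12 log units; within the scatter), within the scatter. Compound 4 is therefore estimated at 200 nM in this assay, with a range from 60 nM to 650 nM.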

Compound 4, half-maximal inhibitory concentration: 27 nM
The estimate for compound 4 lay 7.4-fold (0.87 log units) above the measured number; measured number outside the range, below it.
By their numbers in this assay, from the lowest: compounds 2 and 4 (each within the scatter of the next); then compound 3; then compound 1.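

In this assay, among the compounds shown here, 3-fluoro-2-methylphenyl in place of 2-fluoro-6-methylphenyl on an amide-type nitrogen gives a 5.6-fold lower number from compound 3 to compound 4 (0.74 log units; beyond the scatter), the first single-point step on the amide-side ring, and it lies beyond the scatter. For the compounds shown here, the two groups have the same atoms and the same counts of heavy atoms, hydrogen-bond donors and hydrogen-bond acceptors, so the arrangement of fluoro and methyl on this ring is enough on its own to move the number, which the earlier compounds could not show. Nothing at hand gives a measured property that would explain this step.

The compounds shown leave open whether a chloro or a methoxy group in place of the fluoro of compound 4 would keep the lower number, as only fluoro and methyl appear on the amide-side ring. Going by these compounds alone, they also leave open whether the step carries over to the core of compound 2, where the ring that carries the sulfamate bears a fluoro, as the two changes appear together in no compound here.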